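Chloro for Methyl on the Amide-Side Phenyl Ring

The compounds below may be only part of what the source reports. "The series", "measured", "known", "first", "only" and "open" are said of these compounds alone.

The series shares one core, seen in compound 1 `O=C(Nc1ccc(Cl)c(-c2nnc3c(Cl)cccn23)c1)c1cccc(Cl)c1`, and varies only the aryl group on the carbonyl carbon. In a functional assay on MDA-MB-468 cells (Homo sapiens) for antiproliferative activity, read by MTT assay, with a stated time of 72 h (on this read-out lower numbers stand for stronger inhibition and higher numbers for weaker inhibition), compound 1 gives 54800 nM. Compound 2 `O=C(Nc1ccc(Cl)c(-c2nnc3c(Cl)cccn23)c1)c1ccc(Cl)cc1` reaches only the limit of > 100000 nM in this assay. Compound 3 `Cc1cc(Cl)ccc1C(=O)Nc1ccc(Cl)c(-c2nnc3c(Cl)cccn23)c1` gives 34300 nM in this assay, a value that sits beside compound 1, since a 1.6-fold lower number from compound 1 to compound 3 (0.20 log units; within the scatter). The third value, that of compound 2, is a limit (the limit of > 100000 nM in this assay, at which 1 of the 3 values shown sits).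

Compound 4 `O=C(Nc1ccc(Cl)c(-c2nnc3c(Cl)cccn23)c1)c1ccc(Cl)cc1Cl` differs from compound 3 by chloro in place of methyl on an aromatic carbon. Among the compounds with values here, the closest measured step is the one in which methyl entered at that same carbon: an at least 2.9-fold lower number from compound 2 to compound 3 (0.46 log units; beyond the scatter), the only step here beyond the scatter. Whether chloro at that position keeps that gain is not shown by these three compounds; the 3-chlorophenyl and 4-chlorophenyl pair, an at least 1.8-fold higher number from compound 1 to compound 2 (0.26 log units; that floor lies within the scatter), speaks only to the other ring position. The estimate therefore stays near compound 3, with a step of a 1.2-fold higher number from compound 3 to compound 4 (0.07 log units; within the scatter) expected. Compound 4 is expected at 40000 nM, between 15000 nM and 100000 nM.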

Compound 4, half-maximal inhibitory concentration: 21600 nM
The estimate for compound 4 lay 1.9-fold (0.27 log units) above the measured number; measured number inside the range.
By their numbers in this assay, from the lowest: compounds 4, 3 and 1 (each within the scatter of the next, the first and the last beyond it). At a limit, above all of these: compound 2.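

In this assay chloro and methyl on this aromatic carbon cannot be told apart, with a 1.6-fold lower number from compound 3 to compound 4 (0.20 log units; within the scatter) in the change from 4-chloro-2-methylphenyl to 2,4-dichlorophenyl. Chloro holds the gain over hydrogen that methyl had shown, with an at least 4.6-fold lower number from compound 2 to compound 4 (0.66 log units; beyond the scatter) on this carbon, and the 2,4-dichlorophenyl group also stands clear of the 3-chlorophenyl group, with a 2.5-fold lower number from compound 1 to compound 4 (0.40 log units; beyond the scatter) as a gap that the methyl compound did not open. On these data alone, the value of compound 2 is a limit, so the true size of the gain stays unknown: the limit of > 100000 nM in this assay, at which 1 of the 4 values shown sits.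

As far as these compounds go, how an amine, a methoxy group or a carboxylic acid on this carbon would read remains open. So does whether a bromo group there would also fall in with chloro and methyl.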